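Solubility notes: from compound 2 to compound 4

The source may hold more compounds than are shown below. What is called first, only, known or untested is meant among the compounds shown, and "the series" means these compounds.

Measured so far in a physicochemical assay for solubility, measured as thermodynamic solubility, at pH 7.4; a higher number here means a more soluble compound, a lower number a less soluble compound (three compounds):
compound 1 (`COCCNc1nc(NC(c2ccccc2)c2ccccc2)c2c(n1)C(=O)N(C(C)C)C2`) gives (< 1000 nM), a limit and not a number
compound 2 (`CC(=O)N1CCN(c2nc(NCc3ccccc3)c3c(n2)C(=O)N(C(C)C)C3)CC1`) gives (230000 nM)
compound 3 (`COc1cc(OC(F)(F)F)ccc1CNc1nc(N2CCN(C(C)=O)CC2)nc2c1CN(C(C)C)C2=O`) gives (10000 nM)

Compound 2 holds the higher of the two actual numbers (230000 nM). Compound 3 is the nearest number (10000 nM), lower than compound 2 by more than the scatter. Compound 1 has a limit, not a number (< 1000 nM).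

The next compound to read is compound 4 (`CCOc1ccc([C@@H](C)Nc2nc(N3CCN(C(C)=O)CC3)nc3c2CN(C(C)C)C3=O)cc1`). It carries 1-(4-ethoxyphenyl)ethyl in place of benzyl on a nitrogen on an aromatic ring. Within the data shown here, no two measured compounds differ in one place only, so no measured step sizes this change directly, and any expectation is a rough one. Compound 2 sits at the top of the numbers shown, and the only other number, from compound 3 (10000 nM), is the working guide for the expected direction. In this assay the expected change is a fall beyond the scatter (a 12-fold lower number from compound 2 to compound 4 (1.06 log units; beyond the scatter)). The estimated value for compound 4 is 20000 nM (expected range 4000 nM to 80000 nM).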

Compound 4, solubility: 120000 nM
Compound 4: middle estimate off by 6.0-fold (0.78 log units), on the low side; measured number above the stated range.
By their numbers in this assay, from the lowest: compound 3; then compounds 4 and 2 (each within the scatter of the next). At a limit, below all of these: compound 1.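

Working notes on the step at this nitrogen: in this assay, 1-(4-ethoxyphenyl)ethyl in place of benzyl on a nitrogen on an aromatic ring gives a 1.9-fold lower number from compound 2 to compound 4 (0.28 log units; within the scatter) and is the first one-place step available in the series. The position therefore holds a group of 11 heavy atoms, with 1 hydrogen-bond acceptor and 1 defined stereocentre, in place of benzyl with 7 heavy atoms and no hydrogen-bond acceptor, and the read-out stays within the scatter. Nothing among the measurements shown accounts for this step, and the one limit in the series has no bearing on it.

The ethoxy group, the added branch and the stereocentre enter together, so their separate contributions stay open, as does the mirror-image stereocentre, and compound 3, with another substituted group at this nitrogen, gives 10000 nM with no printed step to explain its place. Also open, as far as these compounds go, is how this position would read in this assay with an amine or a carboxylic acid on the aromatic ring in place of the ethoxy group.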